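Bromine on the Saturated Ring Carbon of Compound 2

The source may report more compounds than this note shows. Statements on the series, on what has been measured and on what is new or still open speak of the compounds shown alone.

Measured so far:
compound 1 `N#CCC(=O)N/N=C(/CBr)c1ccc([N+](=O)[O-])cc1` — 14000 nM
compound 2 `N#CCC1=NN=C(c2ccc([N+](=O)[O-])cc2)CO1` — 1800 nM

In a functional assay on SF-268 cells (Homo sapiens) for inhibition, read by sulforhodamine B assay, with a stated time of 48 h (a lower number here means a stronger inhibitor of growth, a higher number a weaker inhibitor of growth), compound 2 gives the lowest of the two numbers; compound 1 gives a higher number, and the gap between them lies beyond the usual scatter. Compound 3 `N#CCC1=NN=C(c2ccc([N+](=O)[O-])cc2)C(Br)O1` has not yet been measured in this assay. It differs from compound 2 by bromo in place of hydrogen on a saturated ring carbon. Within the data shown here, no single-change step between measured compounds is available, so the expected step of a 1.1-fold higher number from compound 2 to compound 3 (0.05 log units; within the scatter) is taken as none beyond the scatter. Compound 3 is therefore estimated at 2000 nM, within a range from 700 nM to 6000 nM.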

Compound 3, concentration for 50% growth inhibition: 6700 nM
For compound 3 the middle estimate is 3.4-fold (0.53 log units) below the measured one, and the stated range ends below it.
By their numbers in this assay, from the lowest: compound 2; then compound 3; then compound 1.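

Among these compounds, until this result, no single-change step was available in this assay, so the saturated ring carbon next to the ring oxygen had no reading of its own. Bromo in place of hydrogen there gives a 3.7-fold higher number from compound 2 to compound 3 (0.57 log units; beyond the scatter) and so shows that this position is not indifferent to substitution, with growth inhibition modestly weakened. Nothing measured here accounts for the step. From the compounds shown here alone, how a chloro, a methyl or an amine on this same carbon would compare with bromo remains open.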